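The source may hold more compounds than are shown below. What is called first, only, known or untested is meant among the compounds shown, and "the series" means these compounds.

Measured compounds, in a functional assay on SMMC-7721 cells (Homo sapiens) for cytotoxicity, read by MTT assay, with a stated time of 4 days; a lower number here means a stronger inhibitor, a higher number a weaker inhibitor:

compound 1, `Cc1ccc(S(=O)(=O)Oc2ccc3c(c2C)[C@H](Cn2cc(-c4ccccc4)nn2)[C@@]24CC(=O)[C@@](C)(CC[C@@H]32)C4)cc1`: > 20000 nM
compound 2, `Cc1ccc(S(=O)(=O)Oc2ccc3c(c2C)[C@H](Cn2cc(-c4ccc(Br)cc4)nn2)[C@@]24CC(=O)[C@@](C)(CC[C@@H]32)C4)cc1`: > 20000 nM
compound 3, `C=C1C[C@]23C[C@@]1(O)CC[C@H]2c1ccc(O)c(C)c1[C@@H]3Cn1cc(-c2ccc(C)cc2)nn1`: > 20000 nM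

The value of compound 1 is a limit of the assay. The value of compound 2 is a limit as well. The value of compound 3 is likewise a limit; (the limit of > 20000 nM in this assay, at which 3 of the 3 values shown sit). The change bromo in place of hydrogen on an aromatic carbon gives a step that the two limits leave unreadable from compound 1 to compound 2.

Compound 4, `C=C1C[C@]23C[C@@]1(O)CC[C@H]2c1cc(Br)c(O)c(C)c1[C@@H]3Cn1cc(-c2ccc(C)cc2)nn1`, is not yet measured. It differs from compound 3 by bromo in place of hydrogen on an aromatic carbon. The difference between the core of compound 3 and the core of compound 1 is not broken down here. The surroundings of the change are not the same: in compound 2 the bromo sits para to a large group, in compound 4 ortho to a hydroxy group, meta to a fused ring, meta to a methyl group and para to a fused ring, so this is the same kind of change, not the same change. For compound 4 in this assay the step that the limit leaves unreadable from compound 3 to compound 4 is expected, resting on the limit of compound 3 at > 20000 nM and on the unreadable step that the two limits leave unreadable from compound 1 to compound 2. The estimate for compound 4 is 30000 nM, expected between 8000 nM and 100000 nM.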

Compound 4, half-maximal inhibitory concentration: > 20000 nM
Compound 4 gave a limit, no number; the forecaster's own chance of this, stated with the estimate: 80%; the middle value lies beyond the limit too.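

No step can be read from compound 3 to compound 4, as both values in this assay are limits: the limit of > 20000 nM in this assay, at which 4 of the 4 values shown sit.

From the compounds shown here alone, whether bromo in place of hydrogen on an aromatic carbon changes the read-out at all stays open, in this pair and in compound 1 and compound 2.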